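A few compounds are considered here, and "the series" means these few. Any claim that something is new, unique, unknown or untested is made for them only; others in the source may bear on it.

Notes on the series, read in a functional assay on SW1573 cells (Homo sapiens) for antiproliferative activity, read by sulforhodamine B assay, with a stated time of 48 h; on this read-out lower numbers stand for stronger inhibition of growth and higher numbers for weaker inhibition of growth. Compound 1 `CC(C)(C)[Si](C)(C)O[C@@H]1CCCO[C@@H]1/C=C\CO` gives > 100000 nM, which is a limit of the assay. Compound 2 `CC(C)(C)[Si](C)(C)O[C@@H]1CCCO[C@@H]1/C=C/C(=O)O` gives > 100000 nM, also a limit. Among the measured compounds shown here, the only number so far belongs to compound 3 `CC(C)(C)[Si](C)(C)O[C@@H]1CCCO[C@@H]1CC(=O)OCc1ccccc1`, at 30000 nM. The other two results sit at one ceiling: the limit of > 100000 nM in this assay, at which 2 of the 3 values shown sit.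

The next change makes compound 4 `O=C(C[C@H]1OCCC[C@H]1O)OCc1ccccc1` from compound 3: a hydrogen atom in place of a group of 7 heavy atoms (6 carbon, 1 silicon; no ring), on an oxygen on a saturated carbon. For the measured compounds named here, the sole measured step is a step that the two limits leave unreadable from compound 1 to compound 2. Going by the values given here, it gives no size, and the departing group stays in place on both sides of it, so no measured step speaks directly to this removal.

The expectation therefore rests on the position of compound 3 at 30000 nM, and it is held loosely. Little room is left under the ceiling. A modest loss of growth inhibition is expected, and a result reported only as a limit is quite possible. The expected change is a 2.3-fold higher number from compound 3 to compound 4 (0.37 log units; beyond the scatter). The estimate for compound 4 is 70000 nM, with an expected range of 20000 nM to 200000 nM.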

Compound 4, concentration for 50% growth inhibition: > 100000 nM
Compound 4 ended at the assay's limit; the forecaster's own chance of this, stated with the estimate: 50%; at least 1.4-fold (0.15 log units) between middle value and limit.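

In this assay, a hydrogen atom in place of the group of 7 heavy atoms (6 carbon, 1 silicon) on the oxygen gives an at least 3.3-fold higher number from compound 3 to compound 4 (0.52 log units; beyond the scatter). Among the compounds shown here, this is the first readable step, and it shows that the group on this oxygen matters: with only the hydrogen left, the weak growth inhibition of compound 3 is no longer seen up to the ceiling of the assay. The true size of the step stays open, as compound 4 gives a limit and not a number, and that limit now holds most of the series: the limit of > 100000 nM in this assay, at which 3 of the 4 values shown sit.

As far as these compounds go, whether this silicon group is specifically required, or any group on that oxygen would serve, stays open; a methyl ether or a benzoyl ester there would separate the two. Also open, from the compounds shown here alone, is what the benzyl ester contributes, for which a primary amide in its place would be a direct comparison.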